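Solubility notes: from compound 2 to compound 3

The source may hold more compounds than are shown below. What is called first, only, known or untested is meant among the compounds shown, and "the series" means these compounds.

Compound 1 `Cc1cc(C)cc(-c2nc(CN3CCC(C(=O)NCCCN4C[C@H](C)C[C@H](C)C4)CC3)c(C)o2)c1`: > 71 ug/mL
Compound 2 `Cc1cc(-c2nc(CN3CCC(C(=O)NCCCN4C[C@H](C)C[C@H](C)C4)CC3)co2)ccc1F`: > 70 ug/mL

In a physicochemical assay for solubility, in phosphate buffer, measured as kinetic solubility, at pH 7.4 (a higher number here means a more soluble compound, a lower number a less soluble compound), compound 2 reads > 70 ug/mL, which is a limit and not a number. Compound 1 reads > 71 ug/mL, which is also a limit. Among the compounds with values here, the two readings therefore set no order between these compounds, and no measured step is available.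

Compound 3 `Cc1cc(-c2nc(CN3CCC(C(=O)NCCCN4CCC(C(C)C)CC4)CC3)co2)ccc1F` differs from compound 2 in one place: 4-isopropylpiperidin-1-yl in place of 3,5-dimethylpiperidin-1-yl on a saturated chain carbon, three bonds along the chain from an amide-type nitrogen. Here, 4-isopropylpiperidin-1-yl stands in place of 3,5-dimethylpiperidin-1-yl on a saturated chain carbon, three bonds along the chain from an amide-type nitrogen. Expected is an at least 1.0-fold lower number from compound 2 to compound 3 (0.03 log units; that floor lies within the scatter) in this assay, a change within the usual scatter and without a clear direction. Another limit reading is also expected to be more likely than not. The estimate for compound 3 is 65 ug/mL, with an expected range of 30 ug/mL to 80 ug/mL.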

Compound 3, solubility: > 72 ug/mL
Compound 3: only a limit was reported; the forecaster's own chance of this, stated with the estimate: 60%; at least 1.1-fold (0.04 log units) between middle value and limit.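

In this assay compound 3 gives > 72 ug/mL, which is a limit. Compound 2 gives > 70 ug/mL, also a limit, so no step can be read between compound 2 and compound 3. From the compounds shown here alone, whether 4-isopropylpiperidin-1-yl in place of 3,5-dimethylpiperidin-1-yl alters solubility at all remains open.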